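Working notes: from compound 1 to compound 4

This account rests on a few compounds, and the source may have more. Where it says the series, first, only, none or still open, it means among the compounds named here.

Measured so far in a functional assay on SH-SY5Y cells (Homo sapiens) for cytotoxicity, read by MTT assay, with a stated time of 72 h; a higher number here means a weaker inhibitor, a lower number a stronger inhibitor
compound 1 `O=C1c2c[n+]([O-])c3ccccc3c2C(=O)c2c1c1ccccc1n2Cc1cn([C@@H]2C[C@H](O)[C@@H](CO)O2)nn1` gives 150 nM
compound 2 `O=C1c2c[n+]([O-])c3ccccc3c2C(=O)c2c1c1ccccc1n2CCCCN1CCNCC1` gives 1240 nM
compound 3 `CCCCN1CCN(CCCCn2c3c(c4ccccc42)C(=O)c2c[n+]([O-])c4ccccc4c2C3=O)CC1` gives 6100 nM

Compound 1 holds the lowest of the three numbers, and the other two lie well above it. Compound 4 `CC1(C)OC[C@@H](Cn2cc(Cn3c4c(c5ccccc53)C(=O)c3c[n+]([O-])c5ccccc5c3C4=O)nn2)O1` is still unmeasured. It keeps the core of compound 1 and differs in one group on an aromatic nitrogen of a five-membered aromatic ring with 3 nitrogen ((2,2-dimethyl-1,3-dioxolan-4-yl)methyl in place of 4-hydroxy-5-(hydroxymethyl)oxolan-2-yl on an aromatic nitrogen).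

For the measured compounds named here, no measured step makes this replacement. Going by the values given here, the only single-place step available is a 4.9-fold higher number from compound 2 to compound 3 (0.69 log units; beyond the scatter), modest but beyond the scatter. It concerns a butyl group on an amine nitrogen in a ring, so it is only a rough guide to size. Compound 2 (1240 nM) and compound 3 (6100 nM) both lack the 4-hydroxy-5-(hydroxymethyl)oxolan-2-yl group, and both stand above compound 1 (150 nM). A modest move to a higher number in this assay is therefore expected, not a fall, though three compounds cannot settle the direction. The expected change is a 2.3-fold higher number from compound 1 to compound 4 (0.37 log units; beyond the scatter), with wide uncertainty. For compound 4 the estimated value is 350 nM (expected range 110 nM to 1200 nM).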

Compound 4, half-maximal inhibitory concentration: > 1000 nM
Compound 4 ended at the assay's limit (the forecaster's own chance of this, stated with the estimate: 3%); middle value at least 2.8-fold (0.45 log units) away from the limit.
By their numbers in this assay, from the lowest: compound 1; then compound 2; then compound 3.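

In this assay compound 4 gives > 1000 nM, which is a limit of the assay and not a number: the limit of > 1000 nM in this assay, at which 1 of the 4 values shown sits.

For the compounds shown here, the only measured step at this position shows that the group on the aromatic nitrogen of the five-membered aromatic ring with 3 nitrogen is not interchangeable here: (2,2-dimethyl-1,3-dioxolan-4-yl)methyl in place of 4-hydroxy-5-(hydroxymethyl)oxolan-2-yl gives an at least 6.6-fold higher number from compound 1 to compound 4 (0.82 log units; beyond the scatter). The two groups have the same count of 8 heavy atoms, but they differ in other counted features: the leaving group has 2 hydrogen-bond donors and 3 defined stereocentres, while the entering group has 0 hydrogen-bond donors and 1 defined stereocentre, and this single step cannot separate these differences.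

From the compounds shown here alone, the full size of the step stays open, as compound 4 has only a limit in this assay. Also open, going by these compounds, is whether the hydroxy groups themselves matter, which a 2,3-dihydroxypropyl group at the same place could test, and how an amine or a carboxylic acid on a longer chain there would compare with compound 1.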